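The source may report more compounds than this note shows. Statements on the series, on what has been measured and on what is new or still open speak of the compounds shown alone.

Working notes on the series. Compound 1 `O=C(Nc1ccc(Br)cc1)Nc1ccc(Nc2ncnc3[nH]ncc23)cc1`, compound 2 `CC(NC(=O)Nc1ccc(Nc2ncnc3[nH]ncc23)cc1)c1ccccc1` and compound 3 `COc1cccc(NC(=O)Nc2ccc(Oc3ncnc4[nH]ncc34)cc2)c1` share the same core; compound 4 `O=C(Nc1ccc(Oc2ncnc3[nH]ncc23)cc1)Nc1cccc(F)c1` has not yet been measured. In an assay on isolated protein for inhibition of vascular endothelial growth factor receptor 2 (Danio rerio), read by fluorescence and microscopy, with a stated time of 33 h (on this read-out higher numbers stand for weaker inhibition and lower numbers for stronger inhibition), compound 1 gives only a limit of > 100000 nM. In this assay compound 2 likewise gives only a limit of > 100000 nM. In this assay, among the measured compounds shown here, compound 3 gives 82000 nM, the only actual number among the three values shown. The other two values sit at the limit of > 100000 nM in this assay, at which 2 of the 3 values shown sit, so the step that the two limits leave unreadable from compound 1 to compound 2 stays unreadable. Compound 3 thus stands as the one fixed point from which to work. The change from compound 3 to compound 4 is fluoro in place of methoxy on an aromatic carbon. For the measured compounds named here, no measured step bears on this change: the single step available lies on a different part of the molecule and has no readable size. The expected step in this assay is therefore a 1.1-fold higher number from compound 3 to compound 4 (0.04 log units; within the scatter), that is, none beyond the usual scatter. Compound 4 is estimated at 90000 nM in this assay, with a range from 30000 nM to 250000 nM.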

Compound 4, half-maximal inhibitory concentration: 16600 nM
Beside the measured number, compound 4's estimate is 5.4-fold (0.73 log units) above it; measured number below the stated range.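

In this assay, among the compounds shown here, fluoro in place of methoxy on an aromatic carbon, meta to a large group, gives a 4.9-fold lower number from compound 3 to compound 4 (0.69 log units; beyond the scatter) and so provides the first step of readable size. For the compounds shown here, this position therefore responds to the group it carries, which the earlier compounds could not show: the only earlier step cannot be read, and it lies at a different part of the molecule. Nothing measured here bears on why the number falls with this change.

With a single pair at this position, the step cannot be divided between methoxy leaving and fluoro entering. As far as these compounds go, it remains open where chloro, trifluoromethyl, an amine or a carboxylic acid on the same carbon would fall relative to compound 3 and compound 4.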